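Swapping Bromo for Trifluoromethyl on a Receptor Antagonist Scaffold

This account rests on a few compounds, and the source may have more. Where it says the series, first, only, none or still open, it means among the compounds named here.

The measured compounds:
- Compound 1, `CCN(c1nc(C)cc(C)n1)c1c(Br)cc(OC)cc1OC`, gives 12 nM
- Compound 2, `CCN(CC)c1cc(C)nc(N(CC)c2ccc(N(C)C)cc2Br)n1`, gives 27 nM
- Compound 3, `CCCCN(CC#N)c1nc(C)nc(N(CC)c2ccc(N(C)C)cc2C(F)(F)F)n1`, gives 6 nM

All three values come from an assay on isolated protein for binding affinity to corticotropin-releasing factor receptor 1 (Homo sapiens); a lower number here means a stronger inhibitor, a higher number a weaker inhibitor. Among the three, compound 2 stands at the highest number, which makes it the weakest binder of the set. Its nearest neighbour is compound 1, and the gap between them lies beyond the usual scatter of the measurement. Among the compounds with values here, compound 3 lies furthest away, with the lowest number of the three; it differs from compound 2 in several places at once, so its values show only that a compound carrying a trifluoromethyl group can reach a low number, not what any single change contributes.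

Compound 4, `CCN(CC)c1cc(C)nc(N(CC)c2ccc(N(C)C)cc2C(F)(F)F)n1`, has not yet been measured in this assay . It differs from compound 2 in one place: trifluoromethyl in place of bromo on an aromatic carbon. Within the data shown here, no pair of measured compounds shows this exact exchange on its own, so no measured step can be quoted for it. From the standing of compound 2 and the low value of compound 3, a modest move towards a lower number is expected, of a size that could be just beyond the scatter, from compound 2 to compound 4 of about a 1.9-fold lower number from compound 2 to compound 4 (0.29 log units; within the scatter). Compound 4 is estimated at 14 nM, with a plausible range from 5 nM to 40 nM.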

Compound 4, inhibition constant: 11 nM
For compound 4 the middle estimate is 1.3-fold (0.10 log units) above the measured one, within the range that was stated.
By their numbers in this assay, from the lowest: compounds 3, 4 and 1 (each within the scatter of the next); then compound 2.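

The exchange of bromo for trifluoromethyl can now be read on its own: in this assay this single change gives a 2.5-fold lower number from compound 2 to compound 4 (0.39 log units; beyond the scatter) and this modest step lies beyond the usual scatter. Compound 3 also carries trifluoromethyl, but it differs from compound 2 in several places at once, so it could not show what this one group contributes. At this aromatic carbon, ortho to a large group and meta to a dimethylamino group, a group of 4 heavy atoms can take the place of a single bromine with a lower number, and no measurement shown here explains this step.

With only bromo and trifluoromethyl shown at this position, it remains open where a chlorine atom, a methyl group or a methoxy group would fall in this assay. Within the data shown here, it also remains open whether the same exchange would give a step of similar size on the core of compound 1, since this single pair is the only direct reading of the change.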